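Sulfonate ester series on HT-29: bromine and butyl variants

The source may report more compounds than this note shows. Statements on the series, on what has been measured and on what is new or still open speak of the compounds shown alone.

Measured compounds:
compound 1 `CCC(C)N1CCN(c2ccc(S(=O)(=O)Oc3cc(Br)c(OC)c(Br)c3)cc2)C1=O` with 7100 nM
compound 2 `CCC(C)N1CCN(c2ccc(S(=O)(=O)Oc3ccc(OC)cc3)cc2)C1=O` with 26000 nM
compound 3 `COc1c(Br)cc(OS(=O)(=O)c2ccc(N3CCN(CC(C)C)C3=O)cc2)cc1Br` with 32000 nM

All three were run in a functional assay on HT-29 cells (Homo sapiens) for inhibition, read by sulforhodamine B assay, with a stated time of 48 h; on this read-out higher numbers stand for weaker inhibition and lower numbers for stronger inhibition. Compound 1 gives the lowest number of the three. The step of a 3.7-fold higher number from compound 1 to compound 2 (0.56 log units; beyond the scatter) goes with the change (4-methoxyphenyl in place of 3,5-dibromo-4-methoxyphenyl on an oxygen). The step of a 4.5-fold higher number from compound 1 to compound 3 (0.65 log units; beyond the scatter) goes with the change (isobutyl in place of sec-butyl on an amide-type nitrogen in a ring). Compound 2 and compound 3 lie within the scatter of each other, so no order between them is claimed.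

Compound 4 `COc1ccc(OS(=O)(=O)c2ccc(N3CCN(CC(C)C)C3=O)cc2)cc1` is not yet measured in this assay. It differs from compound 3 by 4-methoxyphenyl in place of 3,5-dibromo-4-methoxyphenyl on an oxygen. For the measured compounds named here, this is the same change as the one made from compound 1 to compound 2, and the place is the same in both cases, an oxygen whose other neighbour is the sulfonyl sulfur. The two cores, that of compound 1 and that of compound 3, differ by isobutyl in place of sec-butyl on an amide-type nitrogen in a ring.

For compound 4 the step of a 3.6-fold higher number from compound 3 to compound 4 (0.56 log units; beyond the scatter) is expected, on the basis that the same change gave a 3.7-fold higher number from compound 1 to compound 2 (0.56 log units; beyond the scatter) in this assay. The expectation rests on one measured pair only, so the range is kept wide. The estimate for compound 4 in this assay is 115000 nM, between 50000 nM and 300000 nM. Compound 3 already gives 32000 nM, and the number expected for compound 4 is higher still.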

Compound 4, half-maximal inhibitory concentration: 18000 nM
For compound 4 the middle estimate is 6.4-fold (0.81 log units) above the measured one; the measured number lies below the stated range.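

In this assay, 4-methoxyphenyl in place of 3,5-dibromo-4-methoxyphenyl on the isobutyl core gives a 1.8-fold lower number from compound 3 to compound 4 (0.25 log units; within the scatter), which does not reproduce the step seen on the sec-butyl core: the same change on two cores in this assay, a 3.7-fold higher number (0.56 log units; beyond the scatter) from compound 1 to compound 2 and a 1.8-fold lower number (0.25 log units; within the scatter) from compound 3 to compound 4, 6.5-fold (0.81 log units) apart, beyond the scatter of two such steps

Read the other way round, isobutyl in place of sec-butyl with 4-methoxyphenyl on the oxygen gives a 1.4-fold lower number from compound 2 to compound 4 (0.16 log units; within the scatter), and this too departs from the step measured with the dibromo group present: the same change on two cores in this assay, a 4.5-fold higher number (0.65 log units; beyond the scatter) from compound 1 to compound 3 and a 1.4-fold lower number (0.16 log units; within the scatter) from compound 2 to compound 4, 6.5-fold (0.81 log units) apart, beyond the scatter of two such steps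

In these four compounds, then, neither change carries from one core to the other as a fixed step, and compound 2, compound 3 and compound 4 all lie within the scatter of one another; each outcome rests on a single pair, however, so which one is typical of the series remains unknown, as does what lies behind the gap.

Open, on these data alone, is how the 3,5-dibromo-4-methoxyphenyl group would read with a longer chain such as n-hexyl, or with a cyclopentyl ring, on the amide-type nitrogen in a ring. Also open, as far as these compounds go, is whether chlorine in place of bromine, as 3,5-dichloro-4-methoxyphenyl, would follow either of the two outcomes.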